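This account rests on a few compounds, and the source may have more. Where it says the series, first, only, none or still open, it means among the compounds named here.

Three compounds were measured in a functional assay on HepG2 cells (Homo sapiens) for cytotoxicity, read by MTT assay, with a stated time of 72 h; on this read-out higher numbers stand for weaker inhibition of growth and lower numbers for stronger inhibition of growth:

Compound 1 `C[Se]/C(=N\C(=O)c1cc2ccccc2s1)NC(=O)c1cc2ccccc2s1` gives 9590 nM.
Compound 2 `CS/C(=N\C(=O)c1sccc1Cl)NC(=O)c1sccc1Cl` gives 65300 nM.
Compound 3 `CS/C(=N\C(=O)c1cc2ccccc2s1)NC(=O)c1cc2ccccc2s1` gives 15800 nM.

Compound 3 and compound 1 share a core and differ only in one place: a group of 2 heavy atoms (1 carbon, 1 selenium; no ring) in place of a group of 2 heavy atoms (1 carbon, 1 sulfur; no ring), on a carbon with a double bond to nitrogen. That change gave a 1.6-fold lower number from compound 3 to compound 1 (0.22 log units; within the scatter). Compound 2 has a different core; how its core differs from the core of compound 3 is not broken down here. Compound 4 `C[Se]/C(=N\C(=O)c1sccc1Cl)NC(=O)c1sccc1Cl` is compound 2 with the same change made: a group of 2 heavy atoms (1 carbon, 1 selenium; no ring) in place of a group of 2 heavy atoms (1 carbon, 1 sulfur; no ring), on a carbon with a double bond to nitrogen. The two surroundings match word for word, so this is the same change.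

The step is expected to be small, about a 1.6-fold lower number from compound 2 to compound 4 (0.19 log units; within the scatter), because the matching step on the other core, a 1.6-fold lower number from compound 3 to compound 1 (0.22 log units; within the scatter), stayed within the scatter. Compound 4 is therefore estimated at about 42000 nM, with a plausible range from 16000 nM to 110000 nM.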

Compound 4, concentration for 50% growth inhibition: 690 nM
The estimate for compound 4 lay 61-fold (1.78 log units) above the measured number; the whole stated range lies above it.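

Replacing the methylsulfanyl group with its selenium counterpart gave a 95-fold lower number from compound 2 to compound 4 (1.98 log units; beyond the scatter) in this assay. The size of this change therefore did not carry over from one core to the other: the same change on two cores in this assay, a 1.6-fold lower number (0.22 log units; within the scatter) from compound 3 to compound 1 and a 95-fold lower number (1.98 log units; beyond the scatter) from compound 2 to compound 4, 57-fold (1.76 log units) apart, beyond the scatter of two such steps

So the effect of this swap in this series depends on the core that carries it, and a step measured on one core is a poor guide to the step on another. Among these compounds, with only two pairs, this does not show which part of the core matters or what a third core would give.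

On these data alone, it remains open how a longer chain on the selenium, such as ethyl, would behave, or how an amine would behave on the same carbon.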